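The source may hold more compounds than are shown below. What is called first, only, known or untested is meant among the compounds shown, and "the series" means these compounds.

Measured compounds:
- compound 1 `CCC(CC)C(/C=C1\OC(=O)NC1=O)c1ccc(-c2ccc3cccc(F)c3c2)[nH]c1=O`: 23 nM
- compound 2 `O=C1NC(=O)/C(=C/C(c2ccc(-c3ccc4cccc(F)c4c3)[nH]c2=O)C2CCCC2)O1`: 7 nM

For the measured compounds named here, in a functional assay on CHO cells for antagonist activity at prostaglandin E2 receptor EP3 subtype (Homo sapiens), read by cAMP accumulation, with a stated time of 30 min (on this read-out higher numbers stand for weaker inhibition and lower numbers for stronger inhibition), compound 2 holds the lowest of the two numbers so far; the nearest is compound 1, and the step of a 3.3-fold lower number from compound 1 to compound 2 (0.52 log units; beyond the scatter) lies beyond the scatter, a modest gain from swapping pentan-3-yl for cyclopentyl at the same chain carbon. Compound 3 `O=C1NC(=O)/C(=C/C(Cc2ccccc2)c2ccc(-c3ccc4cccc(F)c4c3)[nH]c2=O)O1` carries the next variation at that carbon: benzyl in place of cyclopentyl on a saturated chain carbon bound to an aromatic carbon and a double-bonded chain carbon. Going by the values given here, only the step of a 3.3-fold lower number from compound 1 to compound 2 (0.52 log units; beyond the scatter) bears on this, since it alters the same position, and it shows that the group there moves the number by a modest amount but not more. Benzyl has no precedent in the series, so the direction is open; a step within the scatter or a modest shift either way is expected. The expected step is a 1.4-fold higher number from compound 2 to compound 3 (0.15 log units; within the scatter). Compound 3 is estimated at 10 nM, with a range from 3 nM to 35 nM.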

Compound 3, half-maximal inhibitory concentration: 200 nM
For compound 3 the middle estimate is 20-fold (1.30 log units) below the measured one; measured number outside the range, above it.
By their numbers in this assay, from the lowest: compound 2; then compound 1; then compound 3.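

In this assay, the saturated chain carbon bound to an aromatic carbon and a double-bonded chain carbon proves much less tolerant than the first pair suggested: benzyl in place of cyclopentyl gives a 29-fold higher number from compound 2 to compound 3 (1.46 log units; beyond the scatter), a far larger shift than the one between the two earlier groups. Benzyl also trails pentan-3-yl, with an 8.7-fold higher number from compound 1 to compound 3 (0.94 log units; beyond the scatter), so among these three groups, both the ring and the open chain without an aromatic ring stand ahead of it. No measurement at hand accounts for this loss.

On these data alone, whether the loss follows from the aromatic ring itself or from the methylene link that carries it remains open; phenyl or cyclohexylmethyl on that carbon would separate the two. As far as these compounds go, how an amine or a carboxylic acid there would read is equally open.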